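The source may hold more compounds than are shown below. What is called first, only, known or untested is meant among the compounds shown, and "the series" means these compounds.

Measured in a functional assay on MDA-MB-231 cells (Homo sapiens) for cytotoxicity, read by MTT assay, with a stated time of 48 h; on this read-out higher numbers stand for weaker inhibition and lower numbers for stronger inhibition:
- compound 1 `O=C(NC1CC1)c1cc(Oc2cccc(NC(=S)Nc3cccc(C(F)(F)F)c3)c2)ccn1` gives 34800 nM
- compound 2 `O=C(NC1CCCCC1)c1cc(Oc2cccc(NC(=S)Nc3cccc(C(F)(F)F)c3)c2)ccn1` gives only a limit, > 100000 nM
- compound 3 `O=C(NCc1ccccc1)c1cc(Oc2cccc(NC(=S)Nc3cccc(C(F)(F)F)c3)c2)ccn1` gives 75000 nM

Compound 3 has the highest of the two numbers actually reported, with compound 1 giving a lower number by a 2.2-fold higher number from compound 1 to compound 3 (0.33 log units; beyond the scatter). Compound 2 sits at the limit (the limit of > 100000 nM in this assay, at which 1 of the 3 values shown sits), and the gap from compound 2 to compound 3 is an at least 1.3-fold lower number from compound 2 to compound 3 (0.12 log units; that floor lies within the scatter). The earlier step of an at least 2.8-fold higher number from compound 1 to compound 2 (0.45 log units; beyond the scatter) went in the same upward direction.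

Compound 4 `O=C(c1cc(Oc2cccc(NC(=S)Nc3cccc(C(F)(F)F)c3)c2)ccn1)N1CCCC1` differs from compound 3 in this way: pyrrolidin-1-yl in place of benzylamino on a carbonyl carbon. Among the compounds with values here, none of the measured steps touches a change of this kind; all three keep a hydrogen on the amide nitrogen and vary only the group attached to it, so they give only a loose guide. Across those steps the numbers stayed weak or moved upward, and a similarly weak result is expected for compound 4, with the step of a 1.2-fold higher number from compound 3 to compound 4 (0.08 log units; within the scatter) expected to stay within the scatter. The estimate for compound 4 in this assay is 90000 nM, expected between 35000 nM and 250000 nM.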

Compound 4, half-maximal inhibitory concentration: 35400 nM
The estimate for compound 4 lay 2.5-fold (0.41 log units) above the measured number; measured number inside the range.
By their numbers in this assay, from the lowest: compounds 1 and 4 (each within the scatter of the next); then compound 3. At a limit, above all of these: compound 2.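

Within the data shown here, compound 4 is the first here whose amide nitrogen carries no hydrogen, and in this assay the numbers show no loss from that change: a 1.0-fold higher number from compound 1 to compound 4 (0.01 log units; within the scatter) is the step for pyrrolidin-1-yl in place of cyclopropylamino, and a 2.1-fold lower number from compound 3 to compound 4 (0.33 log units; beyond the scatter) is a modest move towards stronger inhibition for pyrrolidin-1-yl in place of benzylamino. The step of an at least 2.8-fold lower number from compound 2 to compound 4 (0.45 log units; beyond the scatter) is only a floor on the true difference. Compound 2 gives a limit and not a number: the limit of > 100000 nM in this assay, at which 1 of the 4 values shown sits.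

On these data alone, whether the missing amide hydrogen or the pyrrolidine ring matters more stays open: a dimethylamino group, which has no ring, or a piperidin-1-yl group on the same carbonyl carbon would help separate the two. As far as these compounds go, whether any amide of this kind reaches much lower numbers in this assay also stays open.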